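Three Amides at the Assay Limit, One Oxane Amide Ahead

A few compounds are considered here, and "the series" means these few. Any claim that something is new, unique, unknown or untested is made for them only; others in the source may bear on it.

Three compounds sharing one core have been tested so far in a toxicity assay on THP-1 cells (Homo sapiens) for inhibition; on this read-out lower numbers stand for higher toxicity in this test and higher numbers for lower toxicity in this test:

compound 1 `COc1ccc(-c2cnc(NC(=O)c3ccccc3O)n2C)cc1` – > 100000 nM, a limit of the assay
compound 2 `COc1ccc(-c2cnc(NC(=O)c3cccnc3)n2C)cc1` – > 100000 nM, a limit of the assay
compound 3 `COc1ccc(-c2cnc(NC(=O)c3ccccc3C)n2C)cc1` – > 100000 nM, a limit of the assay

Compound 3 thus stands where the other two stand: its result in this assay is a limit and not a number, and (the limit of > 100000 nM in this assay, at which 3 of the 3 values shown sit). The three steps between the measured compounds, a step that the two limits leave unreadable from compound 1 to compound 2, a step that the two limits leave unreadable from compound 1 to compound 3 and a step that the two limits leave unreadable from compound 2 to compound 3, are all unreadable, since both ends of each step sit at that same limit. None of them gives a size that could be carried forward.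

Compound 4 `COc1ccc(-c2cnc(NC(=O)C3CCOCC3)n2C)cc1` differs from compound 3 by oxan-4-yl in place of 2-methylphenyl on a carbonyl carbon. Among the compounds with values here, no measured step bears on this change with a readable size; the only evidence is that every amide tested so far sits at the limit. The step from compound 3 to compound 4 is therefore expected to be a step that the limit leaves unreadable from compound 3 to compound 4, none beyond the scatter. Compound 4 is expected to give 150000 nM in this assay, most likely again reported as a limit, with a range from 60000 nM to 400000 nM.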

Compound 4, half-maximal cytotoxic concentration: > 100000 nM
Compound 4: a limit, no number; the forecaster's own chance of this, stated with the estimate: 85%; the middle value does not contradict the limit.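

Compound 4 gives a limit and not a number in this assay, so its steps from compound 1, compound 2 and compound 3 cannot be read: the limit of > 100000 nM in this assay, at which 4 of the 4 values shown sit.

The compounds shown leave open whether the group on the carbonyl carbon changes the result in this assay at all, with no number among the four values.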